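Bromo for fluoro on the arylidene ring: measured and expected

A few compounds are considered here, and "the series" means these few. Any claim that something is new, unique, unknown or untested is made for them only; others in the source may bear on it.

Measured in a functional assay on HEp-2 cells (Homo sapiens) for cytotoxicity, read by MTT assay, with a stated time of 72 h, tested at 10 ug/mL; a higher number here means more inhibition of growth at the concentration tested, a lower number less inhibition of growth:
compound 1 `O=C1NC(=S)/C(=C/c2ccc(Br)cc2)S1`: 18.2%
compound 2 `O=C1NC(=S)/C(=C/c2cccc(F)c2)S1`: 20.9%
compound 3 `O=C1NC(=S)/C(=C/c2ccc(F)cc2)S1`: 30.1%

Compound 3 and compound 1 share a core and differ by one change, (bromo in place of fluoro on an aromatic carbon). That change gave a number 11.9 percentage points lower from compound 3 to compound 1 (beyond the scatter). Compound 2 has the same atoms as compound 3 joined differently; the difference between the two cores is not broken down here. Compound 2 and compound 1 lie within the scatter of each other, as do compound 2 and compound 3.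

Compound 4 `O=C1NC(=S)/C(=C/c2cccc(Br)c2)S1` is not yet measured. It differs from compound 2 by bromo in place of fluoro on an aromatic carbon. This is the same kind of change as from compound 3 to compound 1, not the same: there the place is para to a group of 8 heavy atoms, here it is meta to a group of 8 heavy atoms. Among the measured compounds shown here, only the one measured step is available, so the expectation rests on it alone and on compound 2 giving 20.9%. A step of about a number 8.9 percentage points lower from compound 2 to compound 4 (within the scatter) is expected, and compound 4 is estimated at 12%, between 2% and 24%.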

Compound 4, percent growth inhibition at one concentration: 23.6%
The estimate for compound 4 lay 11.6 percentage points below the measured number; low and high end bracket the measured number.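

In this assay, bromo in place of fluoro gave a number 2.7 percentage points higher from compound 2 to compound 4 (within the scatter). Among the compounds shown here, the change therefore cannot be carried from one core to the other as a fixed step, since the two measured pairs disagree: the same change on two cores in this assay, a number 11.9 percentage points lower (beyond the scatter) from compound 3 to compound 1 and a number 2.7 percentage points higher (within the scatter) from compound 2 to compound 4, 14.6 percentage points apart, beyond the scatter of two such steps With only one pair on each core, this does not show what separates the two outcomes, although the place of the group differs between the pairs, and it gives no basis for predicting the step on any further core.

The compounds shown leave open how the ring behaves with a group other than fluoro or bromo in these places, such as chloro, methoxy, nitrile or an amine, and whether any of these would move the number beyond the scatter. Also open is what a carboxylic acid or a longer chain on the ring would do, and whether the disagreement between the two steps would recur on other pairs.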